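Acylthiourea series on the shared core: cytotoxicity notes

A few compounds are considered here, and "the series" means these few. Any claim that something is new, unique, unknown or untested is made for them only; others in the source may bear on it.

Measured so far:
- compound 1, `Nc1ccc2sc(NC(=S)NC(=O)c3cccs3)nc2c1`: 28400 nM
- compound 2, `Nc1ccc2sc(NC(=S)NC(=O)c3ccc([N+](=O)[O-])cc3)nc2c1`: 33200 nM

Both numbers come from a functional assay on MCF7 cells (Homo sapiens) for cytotoxicity, read by MTT assay, with a stated time of 24 h; on this read-out lower numbers stand for stronger inhibition and higher numbers for weaker inhibition. Compound 1 has the lowest number of the two, and compound 2 sits a short way above it, but the gap between them lies within the scatter, so neither can be called more or less active than the other. On these two points the series is weak, with both numbers high on the read-out.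

The next compound, compound 3, `Nc1ccc2sc(NC(=S)NC(=O)N3CCOCC3)nc2c1`, keeps the shared core and changes only the acyl end of the thiourea: morpholin-4-yl in place of thiophen-2-yl on a carbonyl carbon. Among the compounds with values here, no measured pair differs in one place, so there is no step to lean on. Within the data shown here, the only guide is that compound 1 and compound 2, which differ at the same end, give numbers within the scatter of each other. From that, a change of no more than the scatter is expected in this assay, with a slight lean toward a higher number. Compound 3 is estimated at 40000 nM, range 15000 nM to 110000 nM, meaning an expected step of a 1.4-fold higher number from compound 1 to compound 3 (0.15 log units; within the scatter).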

Compound 3, half-maximal inhibitory concentration: 26400 nM
Compound 3: the middle estimate sits 1.5-fold (0.18 log units) above what was measured, and the stated range covers the measured number.
By their numbers in this assay, from the lowest: compounds 3, 1 and 2 (each within the scatter of the next).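

In this assay, morpholin-4-yl in place of thiophen-2-yl on a carbonyl carbon gives a 1.1-fold lower number from compound 1 to compound 3 (0.03 log units; within the scatter), so this change produces no readable shift at this position. A five-membered aromatic ring and a six-membered non-aromatic ring with two hetero atoms are not told apart here by this read-out, and compound 3, like compound 1, lies high on it, so the new group does not lift the series out of its weak range. No measurement at hand offers an explanation for this result.

Still open, as far as these compounds go, is whether any group on this carbonyl carbon can move the number beyond the scatter, for example a dimethylamino group, a longer chain such as butyl, or a phenyl ring bearing a carboxylic acid. Also open, from the compounds shown here alone, is whether a change elsewhere on the shared core would do more than the changes at the acyl end of the thiourea seen so far.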